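This account rests on a few compounds, and the source may have more. Where it says the series, first, only, none or still open, it means among the compounds named here.

Working notes on the series. In a functional assay on MCF7 cells (Homo sapiens) for antiproliferative activity, read by MTT assay, with a stated time of 48 h (a higher number here means a weaker inhibitor, a lower number a stronger inhibitor), compound 3 (`Fc1ccc(-c2nn(-c3ccccc3)cc2-c2nc3cc(Cl)ccc3[nH]2)cc1`) gives 2230 nM. That value lies within the scatter of its two nearest neighbours, compound 1 (`COc1ccc2[nH]c(-c3cn(-c4ccccc4)nc3-c3ccccc3)nc2c1`) at 1590 nM and compound 2 (`Fc1ccc(-c2nn(-c3ccccc3)cc2-c2nc3ccccc3[nH]2)cc1`) at 3200 nM.

The next change leads to compound 4 (`COc1ccc2[nH]c(-c3cn(-c4ccccc4)nc3-c3ccc(F)cc3)nc2c1`), with methoxy in place of chloro on an aromatic carbon.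

Among the measured compounds shown here, only one measured step bears directly on this position: a 1.4-fold lower number from compound 2 to compound 3 (0.16 log units; within the scatter). It installed the chloro with hydrogen as the starting point and stayed within the scatter, so losing the chloro gives no reason to expect a large shift. For the measured compounds named here, no measured step isolates the methoxy group. Compound 1 carries that group and gives 1590 nM, which offers no sign of a sharp departure from the values seen so far. On these data alone, the data remain thin, with three compounds and a single matched step, so the expectation in this assay is no change beyond the scatter, and the direction stays open.

The expected size of the change is a 1.2-fold lower number from compound 3 to compound 4 (0.07 log units; within the scatter), a step within the scatter. The estimated value for compound 4 is 1900 nM, with an expected range from 850 nM to 4200 nM.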

Compound 4, half-maximal inhibitory concentration: 970 nM
For compound 4 the middle estimate is 2.0-fold (0.29 log units) above the measured one, within the range that was stated.
By their numbers in this assay, from the lowest: compounds 4, 1, 3 and 2 (each within the scatter of the next, the first and the last beyond it).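

In this assay, among the compounds shown here, the methoxy group is the first change at this position to give a step beyond the scatter: a 2.3-fold lower number from compound 3 to compound 4 (0.36 log units; beyond the scatter) against chloro and a 3.3-fold lower number from compound 2 to compound 4 (0.52 log units; beyond the scatter) against hydrogen, whereas the earlier chloro step, a 1.4-fold lower number from compound 2 to compound 3 (0.16 log units; within the scatter), stayed within it. The position therefore responds to at least one substituent, and among the compounds shown the order of the groups there runs from methoxy, with the lowest number, to hydrogen, with chloro within the scatter of each. For the compounds shown here, the new compound also gives the first matched reading of the fluoro group, a 1.6-fold lower number from compound 1 to compound 4 (0.21 log units; within the scatter), which stays within the scatter and leaves the two methoxy compounds without a clear separation, and nothing at hand accounts for the difference between methoxy and chloro.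

On these data alone, whether an ethoxy group, a longer alkoxy chain or an amine at this position would move the number further remains open. So does whether the methoxy step holds on a core without the fluoro group, since only one matched comparison of methoxy against chloro or hydrogen is available.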